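The compounds below may be only part of what the source reports. "The series", "measured", "known", "first", "only" and "open" are said of these compounds alone.

In a functional assay on cells (Leukemia cell, Homo sapiens) for cytotoxicity, read by sulforhodamine B assay, with a stated time of 48 h (on this read-out higher numbers stand for weaker inhibition of growth and lower numbers for stronger inhibition of growth), three compounds of one core have been measured. Compound 1 `O=C1N=C(N2N=C(c3ccccc3)CC2c2ccccc2O)S/C1=C1/C(=O)Nc2ccccc21` gives 48800 nM. Compound 2 `COc1ccc(C2CC(c3ccccc3)=NN2C2=NC(=O)/C(=C3\C(=O)Nc4ccccc43)S2)cc1` gives 20800 nM, a step of a 2.3-fold lower number from compound 1 to compound 2 (0.37 log units; beyond the scatter). Compound 3 `COc1ccc(C2=NN(C3=NC(=O)/C(=C4\C(=O)Nc5ccccc54)S3)C(c3ccc(OC)cc3)C2)cc1` gives 100000 nM, the highest number of the three, after a step of a 4.8-fold higher number from compound 2 to compound 3 (0.68 log units; beyond the scatter); it therefore shows the weakest growth inhibition of this set. Going by the values given here, compound 4 `COc1ccc(C2=NN(C3=NC(=O)/C(=C4\C(=O)Nc5ccc(Cl)cc54)S3)C(c3ccc(OC)cc3)C2)cc1` differs from compound 3 only by chloro in place of hydrogen on an aromatic carbon, a position on the fused ring that none of the measured steps touches; both measured steps concern the aryl groups on the other ring. Among the compounds with values here, there is thus no direct precedent for this change, and the estimate for compound 4 is 90000 nM, with a range of 35000 nM to 200000 nM. The expected step in this assay is a 1.1-fold lower number from compound 3 to compound 4 (0.05 log units; within the scatter), which is not beyond the scatter.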

Compound 4, concentration for total growth inhibition: 75200 nM
Compound 4: the middle estimate sits 1.2-fold (0.08 log units) above what was measured; measured number inside the range.
By their numbers in this assay, from the lowest: compound 2; then compounds 1, 4 and 3 (each within the scatter of the next, the first and the last beyond it).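

Putting chloro in place of hydrogen on this aromatic carbon of the fused ring gives a 1.3-fold lower number from compound 3 to compound 4 (0.12 log units; within the scatter) in this assay, so this change cannot be told apart from no change. The two earlier steps, both on the aryl groups of the other ring, lay beyond the scatter, whereas this first change on the fused ring does not. No available evidence bears on this result.

Going by these compounds, whether this position would accept a larger change, such as an amine, a carboxylic acid or a longer chain, stays open. So does whether chloro would act the same way on compound 2.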